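The compounds below may be only part of what the source reports. "The series", "measured", "known", "first", "only" and "open" are said of these compounds alone.

Measured in a functional assay on A-375 cells (Homo sapiens) for antiproliferative activity, read by MTT assay, with a stated time of 24 h; on this read-out higher numbers stand for weaker inhibition and lower numbers for stronger inhibition:
- compound 1 `COc1cc(OC)c(-c2coc3cc(OCc4ccccc4)ccc3c2=O)cc1OC`: 1640 nM
- compound 2 `COc1cc(OC)c(-c2coc3cc(OCc4ccc(Br)cc4)ccc3c2=O)cc1OC`: 1000 nM
- compound 3 `COc1cc(OC)c(-c2coc3cc(OCc4ccccc4C(F)(F)F)ccc3c2=O)cc1OC`: > 10000 nM (a limit)

Compound 3 gives only a limit, > 10000 nM, and no number. Compound 4 `COc1cc(OC)c(-c2coc3cc(OCc4ccccc4Cl)ccc3c2=O)cc1OC` differs from compound 3 by chloro in place of trifluoromethyl on an aromatic carbon, ortho to a large group. Among the measured compounds shown here, two steps bear most directly on this: an at least 6.0-fold higher number from compound 1 to compound 3 (0.78 log units; beyond the scatter) and an at least 10-fold higher number from compound 2 to compound 3 (1.00 log units; beyond the scatter), both beyond the scatter. A halogen elsewhere gave only a 1.6-fold lower number from compound 1 to compound 2 (0.21 log units; within the scatter), within the scatter. Compound 4 is therefore expected to recover part of the loss seen at compound 3, with a lower number in this assay. The expected change is an at least 3.3-fold lower number from compound 3 to compound 4 (0.52 log units; beyond the scatter). For compound 4 the estimated value is 3000 nM, with an expected range of 900 nM to 10000 nM.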

Compound 4, half-maximal inhibitory concentration: 2020 nM
Compound 4: middle estimate off by 1.5-fold (0.17 log units), on the high side; the range from low to high includes it.
By their numbers in this assay, from the lowest: compounds 2, 1 and 4 (each within the scatter of the next, the first and the last beyond it). At a limit, above all of these: compound 3.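

In this assay the place ortho to a large group accepts chloro (an at least 4.9-fold lower number from compound 3 to compound 4 (0.69 log units; beyond the scatter)), so the loss at compound 3 goes with trifluoromethyl, not with this place being filled. Chloro here shows no change from hydrogen (a 1.2-fold higher number from compound 1 to compound 4 (0.09 log units; within the scatter)), while the comparison with the 4-bromophenyl compound gives a modest step (a 2.0-fold higher number from compound 2 to compound 4 (0.31 log units; beyond the scatter)). Compound 3 stands only at a limit, so its step to compound 4 has no upper size: the limit of > 10000 nM in this assay, at which 1 of the 4 values shown sits.

Open, on these data alone, is whether methoxy or an amine at this place would track chloro or trifluoromethyl. Also open, as far as these compounds go, is whether chloro and bromo differ when they sit on the same ring position.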